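The compounds below may be only part of what the source reports. "The series", "measured", "known", "first", "only" and "open" are said of these compounds alone.

Compound 1 `CCOC(=O)N1CCN(C(=S)SCC(O)Cn2c([N+](=O)[O-])cnc2C)CC1` carries ethoxycarbonyl on an amine nitrogen in a ring. In a toxicity assay on HeLa cells (Homo sapiens) for cytotoxicity, read by MTT assay, with a stated time of 24 h (a lower number here means a stronger inhibitor, a higher number a weaker inhibitor), compound 1 gives 1610000 nM. Among the measured compounds shown here, compound 3 `Cc1ncc([N+](=O)[O-])n1CC(O)CSC(=S)N1CCN(c2ccccn2)CC1` gives 2970000 nM, and these are the only two actual numbers so far, within the scatter of each other. Compound 2 `CCN1CCN(C(=S)SCC(O)Cn2c([N+](=O)[O-])cnc2C)CC1` reads > 5000000 nM, which is a limit of the assay and not a number.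

Compound 4 `Cc1ncc([N+](=O)[O-])n1CC(O)CSC(=S)N1CCN(c2ncccn2)CC1` is still unmeasured. It has pyrimidin-2-yl in place of ethoxycarbonyl on that same nitrogen: pyrimidin-2-yl in place of ethoxycarbonyl on an amine nitrogen in a ring. The closest measured change puts pyridin-2-yl there, another six-membered aromatic ring, and gives a 1.8-fold higher number from compound 1 to compound 3 (0.27 log units; within the scatter). Ethyl is a less close match, although it gives an at least 3.1-fold higher number from compound 1 to compound 2 (0.49 log units; beyond the scatter). Compound 4 is therefore expected to sit near compound 3 because the pyridin-2-yl swap gave a 1.8-fold higher number from compound 1 to compound 3 (0.27 log units; within the scatter). No step beyond the scatter is expected, and the estimated change is a 1.7-fold higher number from compound 1 to compound 4 (0.24 log units; within the scatter). For compound 4 the estimated value is 2800000 nM, with an expected range from 1400000 nM to 5000000 nM.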

Compound 4, half-maximal inhibitory concentration: 2040000 nM
The estimate for compound 4 lay 1.4-fold (0.14 log units) above the measured number; the range from low to high includes it.
By their numbers in this assay, from the lowest: compounds 1, 4 and 3 (each within the scatter of the next). At a limit, above all of these: compound 2.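

In this assay, pyrimidin-2-yl on this amine nitrogen in a ring reads much like ethoxycarbonyl, with a 1.3-fold higher number from compound 1 to compound 4 (0.10 log units; within the scatter), and much like pyridin-2-yl, with a 1.5-fold lower number from compound 3 to compound 4 (0.16 log units; within the scatter). These three groups therefore cannot be told apart here, even though ethoxycarbonyl has no ring and the other two each bring an aromatic ring. Ethyl does separate from pyrimidin-2-yl, with an at least 2.4-fold lower number from compound 2 to compound 4 (0.38 log units; beyond the scatter), and the reading for compound 2 is a limit of the assay and not a number: the limit of > 5000000 nM in this assay, at which 1 of the 4 values shown sits.

As far as these compounds go, it remains open whether a phenyl ring, with no nitrogen in the aromatic ring, or a carboxylic acid or a longer chain on this nitrogen would read like these groups. From the compounds shown here alone, it also remains open whether the same closeness holds in any cell line other than the one in this assay.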